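The source may report more compounds than this note shows. Statements on the series, on what has been measured and on what is new or still open speak of the compounds shown alone.

The three compounds share one core: a chalcone-type chain joined to a five-membered ring that carries two nitrogens and a pendant aromatic group. Compound 1 `COc1cc(/C=C/C(=O)c2cccc(-n3cc(-c4ccc(Cl)cc4)[nH]c3=O)c2)ccc1O` carries a chlorophenyl on that ring. Compound 2 `COc1cc(/C=C/C(=O)c2cccc(-n3cc(-c4ccccc4)[nH]c3=O)c2)cc(OC)c1OC` carries a plain phenyl there and three methoxy groups at the far end of the chain. Compound 3 `O=C(/C=C/c1cccc(O)c1)c1cccc(-n2cc(-c3ccc(Cl)cc3)[nH]c2=O)c1` carries a chlorophenyl and a single hydroxyl at the far end.

In a functional assay on PC-3 cells (Homo sapiens) for inhibition (on this read-out higher numbers stand for weaker inhibition of growth and lower numbers for stronger inhibition of growth), compound 1 gives 1950 nM. In this assay compound 2 gives 3260 nM; of the two numbers recorded, this is the one at the top, but the gap to compound 1 lies within the usual scatter, so the two cannot be told apart. For compound 3 this assay reports "not determined" (no result reported), so no number is available.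

Compound 4 `COc1cc(/C=C/C(=O)c2cccc(-n3cc(-c4cc(OC)c(OC)c(OC)c4)[nH]c3=O)c2)cc(OC)c1OC` is compound 2 with one change: 3,4,5-trimethoxyphenyl in place of phenyl on an aromatic carbon. No pair of measured compounds shows what such a change does here, and nothing in the two numbers shown points in either direction. The step from compound 2 to compound 4 is therefore expected to stay within the scatter, a 1.1-fold lower number from compound 2 to compound 4 (0.04 log units; within the scatter). Compound 4 is expected to give about 3000 nM in this assay, with a likely range from 1200 nM to 8000 nM.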

Compound 4, concentration for 50% growth inhibition: 2630 nM
For compound 4 the middle estimate is 1.1-fold (0.06 log units) above the measured one; low and high end bracket the measured number.
By their numbers in this assay, from the lowest: compounds 1, 4 and 2 (each within the scatter of the next).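

Among the compounds shown here, measured in this assay the step to 3,4,5-trimethoxyphenyl in place of phenyl is a 1.2-fold lower number from compound 2 to compound 4 (0.09 log units; within the scatter) and it gives the first direct reading at this position, on an aromatic carbon of the five-membered aromatic ring. The incoming group has 12 heavy atoms against 6 and 3 hydrogen-bond acceptors against 0, yet this read-out does not separate the two compounds, so at least this one large substituent is accommodated with no measurable difference in growth inhibition. Nothing available explains this outcome, and no independent measurement bears on it.

As far as these compounds go, one step at one position says little about the position in general, since both groups are aromatic rings of carbon only, and it remains open whether a carboxylic acid or an amine on that ring, or a longer alkyl chain in its place, would give a number beyond the scatter. The effect of chlorine on the pendant ring also stays unresolved, as compound 1 differs from compound 2 in more than one place and compound 3 has no number.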